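The source may report more compounds than this note shows. Statements on the series, on what has been measured and on what is new or still open speak of the compounds shown alone.

Compound 1 `Cc1cc(S(N)(=O)=O)ccc1NC(=O)COc1ccc(Cl)cc1C(O)c1cccc(Cl)c1` in an ADME assay on C8166 cells (Homo sapiens) for cytotoxicity, read by MTT assay; a lower number here means that less compound is tolerated, a higher number that more compound is tolerated: 33300 nM
Compound 2 `Cc1cc(S(N)(=O)=O)ccc1NC(=O)COc1ccc(Cl)cc1C(O)c1cccc(C)c1C` in this assay: 218000 nM

Of these two compounds, compound 2 has the higher number at 218000 nM, so more of it is tolerated by the cells in this assay. Compound 3 `Cc1ccc(C)c(C(O)c2cc(Cl)ccc2OCC(=O)Nc2ccc(S(N)(=O)=O)cc2C)c1` has the same atoms as compound 2, joined differently: 2,5-dimethylphenyl in place of 2,3-dimethylphenyl on a saturated chain carbon bound to an aromatic carbon and an oxygen on a saturated carbon. Here 2,5-dimethylphenyl replaces 2,3-dimethylphenyl.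

Among the measured compounds shown here, only one measured step bears on this change: a 6.5-fold higher number from compound 1 to compound 2 (0.82 log units; beyond the scatter). It is modest but beyond the scatter, and it comes from putting 2,3-dimethylphenyl in place of 3-chlorophenyl on the same carbon. The new change is a different kind of swap, since a dimethylphenyl group stays in place and only its pattern differs. For the measured compounds named here, no measured pair shows what such a swap does by itself. Going by the values given here, a smaller step than the one seen with compound 2 218000 nM is therefore expected, with no firm direction and probably nothing beyond the scatter. The expected change is a 1.1-fold lower number from compound 2 to compound 3 (0.06 log units; within the scatter). For compound 3 the estimated value is 190000 nM, with an expected range from 70000 nM to 400000 nM.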

Compound 3, half-maximal cytotoxic concentration: 35500 nM
The estimate for compound 3 lay 5.4-fold (0.73 log units) above the measured number; measured number outside the range, below it.
By their numbers in this assay, from the lowest: compounds 1 and 3 (each within the scatter of the next); then compound 2.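

In this assay, exchanging 2,3-dimethylphenyl for 2,5-dimethylphenyl keeps the same atoms and joins them differently, yet it gives a 6.1-fold lower number from compound 2 to compound 3 (0.79 log units; beyond the scatter). This shows that the arrangement of the methyl groups on this ring can matter here, with a step beyond the scatter, whereas the earlier step, a 6.5-fold higher number from compound 1 to compound 2 (0.82 log units; beyond the scatter), could only show the effect of exchanging 3-chlorophenyl for a different group. The third comparison, a 1.1-fold higher number from compound 1 to compound 3 (0.03 log units; within the scatter), lies within the scatter, so among these compounds the higher tolerated concentration belongs to compound 2 alone and does not extend to both dimethylphenyl groups, although nothing presented here accounts for the difference between them.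

From the compounds shown here alone, it remains open whether 2,3-dichlorophenyl or 2-methoxyphenyl on this same carbon would resemble compound 2 or compound 3 in this assay. Among the compounds shown here, with only three compounds, it also remains open whether the difference between the 2,3-dimethylphenyl and 2,5-dimethylphenyl groups would hold on a core carrying another group in place of the sulfonamide.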